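The source may hold more compounds than are shown below. What is called first, only, known or untested is meant among the compounds shown, and "the series" means these compounds.

Measured compounds:
Compound 1 `Nc1nc(OCC2CC2)c2ncn(/C=C3/C[C@@H]3CO)c2n1`: 112000 nM
Compound 2 `CCCOc1nc(N)nc2c1ncn2/C=C1/C[C@@H]1CO`: 69400 nM

Among the measured compounds shown here, in a functional assay on HFF cells (Homo sapiens) for cytotoxicity (a higher number here means that more compound is tolerated, a lower number that less compound is tolerated), compound 2 gives 69400 nM, which lies within the scatter of compound 1, the only other compound measured. Compound 3 `C#CCNc1nc(N)nc2c1ncn2/C=C1/C[C@@H]1CO` has propargylamino in place of propoxy on an aromatic carbon. For the measured compounds named here, only one measured step bears on this change, and only indirectly: a 1.6-fold lower number from compound 1 to compound 2 (0.21 log units; within the scatter). That step has ethyl in place of cyclopropyl on a saturated chain carbon, so it alters the chain but not the atom joining it to the ring. Going by the values given here, no measured compound shows what the swap of oxygen for nitrogen or the triple bond does in this assay. On this thin evidence, no change beyond the scatter is expected, and the estimated step is a 1.2-fold lower number from compound 2 to compound 3 (0.06 log units; within the scatter). For compound 3 the estimated value is 60000 nM, with an expected range of 20000 nM to 150000 nM.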

Compound 3, half-maximal cytotoxic concentration: 306000 nM
Estimate against measurement, compound 3: 5.1-fold (0.71 log units) below, and the stated range ends below it.
By their numbers in this assay, from the lowest: compounds 2 and 1 (each within the scatter of the next); then compound 3.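

In this assay, the group on this aromatic carbon proves able to move the number: propargylamino in place of propoxy gives a 4.4-fold higher number from compound 2 to compound 3 (0.64 log units; beyond the scatter), and propargylamino in place of cyclopropylmethoxy gives a 2.7-fold higher number from compound 1 to compound 3 (0.44 log units; beyond the scatter). Among the compounds shown here, both steps lie beyond the scatter, whereas the only earlier step, which altered the chain while keeping the oxygen, stayed within it, so compound 3 stands apart from the two ethers with the highest number of the three. Nothing available explains this rise.

The change replaces the oxygen with nitrogen and also brings in the triple bond, so the compounds shown cannot say which of the two carries the step. Propylamino and propargyloxy on this carbon would separate them, and whether a longer alkynylamino chain behaves alike remains open.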